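Swapping the Ester Chain on a Shared Core

The source may report more compounds than this note shows. Statements on the series, on what has been measured and on what is new or still open speak of the compounds shown alone.

Compound 1, `CCNC(=O)C1=C(C)NC(=O)NC1c1ccoc1`, gives 1% in an assay on membranes from HeLa cells for displacement of a labelled ligand from adenosine receptor A3 (Homo sapiens), read by scintillation counting, with a stated time of 180 min, tested at 1 uM; a higher number here means more inhibition at the concentration tested (going by the name of the read-out), a lower number less inhibition.
Compound 2, `CC1=C(C(=O)NC(C)C)C(c2ccoc2)NC(=O)N1`, gives 3% in this assay.
Compound 3, `CCC(CC)OC(=O)C1=C(C)NC(=O)NC1c1ccoc1`, gives 5% in this assay.

Compound 3 shows the highest number of the three, but the gap to compound 2 and the gap to compound 1 both lie within the scatter, so the three cannot be told apart on these numbers. All three numbers are level with one another at the concentration tested.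

Compound 4, `CC1=C(C(=O)OCC2CC2)C(c2ccoc2)NC(=O)N1`, has not yet been measured. It differs from compound 3 in one place: cyclopropylmethyl in place of pentan-3-yl on an oxygen next to a carbonyl group. The steps that speak to this change are those that also alter the group on the carbonyl carbon: a number 4 percentage points higher from compound 1 to compound 3 (within the scatter) and a number 2 percentage points higher from compound 2 to compound 3 (within the scatter), both within the scatter. Exchanging an amide for an ester did nothing measurable, so a change in the ester chain alone is expected to do no more, with no step beyond the scatter expected in this assay, that is, an expected step of no change at the digits printed from compound 3 to compound 4 (within the scatter). Compound 4 is therefore estimated at 5%, between 0% and 13%.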

Compound 4, a percentage reported as inhibition, at one concentration (the size of the read-out at that concentration, not a potency): 3%
Compound 4: middle estimate off by 2 percentage points, on the high side; the measured number falls inside the stated range.
By their numbers in this assay, from the lowest: compounds 1, 2, 4 and 3 (each within the scatter of the next).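

Among the compounds shown, only compound 3 and compound 4 differ within the ester chain itself, and in this assay cyclopropylmethyl in place of pentan-3-yl gives a number 2 percentage points lower from compound 3 to compound 4 (within the scatter) on the shared core. Set against the amides, the new ester shows no change at the digits printed from compound 2 to compound 4 (within the scatter) and a number 2 percentage points higher from compound 1 to compound 4 (within the scatter) in the same read-out, so a chain carrying a three-membered ring reads level with the open pentan-3-yl chain and with both amides. No supporting measurement bears on why these numbers stay level.

The compounds shown leave open whether any group on this carbonyl carbon can lift the number clear of the scatter at the concentration tested. A benzyl ester, a longer straight chain or a carboxylic acid in this place would put that question to the test.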